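This account rests on a few compounds, and the source may have more. Where it says the series, first, only, none or still open, it means among the compounds named here.

Measured compounds:
compound 1, `CCCCCCC[C@H]1C[C@H](Br)CCN1S(=O)(=O)c1ccc(C)cc1` — in a functional assay on SW1573 cells (Homo sapiens) for antiproliferative activity, read by sulforhodamine B assay, with a stated time of 48 h (on this read-out higher numbers stand for weaker inhibition of growth and lower numbers for stronger inhibition of growth), compound 1 gives only a limit, > 100000 nM.
compound 2, `Cc1ccc(S(=O)(=O)N2CC[C@@H](Br)C[C@@H]2C2CCCCC2)cc1` — in this assay compound 2 gives 82000 nM.
compound 3, `CCCCCCCC1C=C(Cl)CCN1S(=O)(=O)c1ccc(C)cc1` — in this assay compound 3 gives 49000 nM.

Going by the values given here, the one measured step here is cyclohexyl in place of heptyl on a saturated ring carbon. In this assay it gave an at least 1.2-fold lower number from compound 1 to compound 2 (0.08 log units; that floor lies within the scatter), a floor that rests on the limit of > 100000 nM in this assay, at which 1 of the 3 values shown sits, rather than on a number for compound 1. Compound 2 and compound 3 sit close to each other on this read-out, and nothing is made of any order between them.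

Compound 3 carries a different core from compound 1, a chloro group and a ring double bond; the difference between the two cores is not broken down here.

Compound 4, `Cc1ccc(S(=O)(=O)N2CCC(Cl)=CC2C2CCCCC2)cc1`, is the unmeasured partner of compound 3: cyclohexyl in place of heptyl on a saturated ring carbon. Among the compounds with values here, this is the same kind of change as the one from compound 1 to compound 2, but not the same: around the place, the new group stands two ring bonds from the ring atom that bears a chloro group rather than a bromo group.

Since the earlier step of an at least 1.2-fold lower number from compound 1 to compound 2 (0.08 log units; that floor lies within the scatter) was small and could only be given as a floor, the step from compound 3 to compound 4 is expected to be small as well, estimated as a 1.2-fold lower number from compound 3 to compound 4 (0.09 log units; within the scatter). Compound 4 is therefore expected to give about 40000 nM in this assay, estimated between 15000 nM and 100000 nM.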

Compound 4, concentration for 50% growth inhibition: 62000 nM
For compound 4 the middle estimate is 1.6-fold (0.19 log units) below the measured one; measured number inside the range.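

In this assay, cyclohexyl in place of heptyl on the core of compound 3 gave a 1.3-fold higher number from compound 3 to compound 4 (0.10 log units; within the scatter), so on this core the change leaves the two compounds indistinguishable on this read-out. Set beside the same change on the core of compound 1, the comparison reads: the same change on two cores in this assay, an at least 1.2-fold lower number (0.08 log units; that floor lies within the scatter) from compound 1 to compound 2 and a 1.3-fold higher number (0.10 log units; within the scatter) from compound 3 to compound 4; the limit leaves it open whether they differ The series therefore offers no sign that this change moves growth inhibition on the core of compound 3, but it does not show that the change acts alike on both cores, and the comparison depends on compound 1, which gives only a limit rather than a number: the limit of > 100000 nM in this assay, at which 1 of the 4 values shown sits.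

Heptyl and cyclohexyl are both groups of carbon only, so it stays open what an amine, a carboxylic acid or a phenyl ring at this place on the ring would do in this assay. Also open is what the chloro group and the ring double bond each contribute apart from one another, since the compounds shown include no core with a bromo group together with a ring double bond and none with a chloro group on a saturated ring.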